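Replacing Hydroxy with Nitro on a Weak Growth Inhibitor

The compounds below may be only part of what the source reports. "The series", "measured", "known", "first", "only" and "open" are said of these compounds alone.

Compounds in this series are compared in a functional assay on HeLa cells (Homo sapiens) for antiproliferative activity, read by MTT assay, with a stated time of 48 h; a higher number here means a weaker inhibitor of growth, a lower number a stronger inhibitor of growth. There, compound 2 `COc1ccc(/C=C2\Cc3cc(OC)c(OC)c(OC)c3C2=O)cc1O` gives > 10000 nM. This is a limit of the assay and not a number.

Compound 3 `COc1ccc(/C=C2\Cc3cc(OC)c(OC)c(OC)c3C2=O)cc1[N+](=O)[O-]` keeps the core of compound 2 and has nitro in place of hydroxy on an aromatic carbon, ortho to a methoxy group (nitro in place of hydroxy on an aromatic carbon). Among the measured compounds shown here, no measured pair of compounds differing in one place shows what such a swap does, so any forecast is loose.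

For the measured compounds named here, the only other measured compound, compound 1 `COc1ccc(/C=C2\Cc3c(cc(OC)c(OC)c3OC)C2=O)cc1[N+](=O)[O-]`, also carries a nitro group and gives 790 nM in this assay. That number suggests some growth inhibition may appear, but compound 3 could also stay at the limit.

The expected change is modest, towards stronger inhibition, and is estimated as an at least 1.6-fold lower number from compound 2 to compound 3 (0.22 log units; that floor lies within the scatter). Compound 3 is expected to give 6000 nM, with an estimated range of 1500 nM to 20000 nM.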

Compound 3, concentration for 50% growth inhibition: > 10000 nM
Compound 3 gave a limit, no number; the forecaster's own chance of this, stated with the estimate: 40%; middle value at least 1.6-fold (0.22 log units) away from the limit.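

In this assay, compound 2 and compound 3 each give a limit of the assay and not a number, so no step can be read between them: the limit of > 10000 nM in this assay, at which 2 of the 3 values shown sit.

The compounds shown leave open what nitro in place of hydroxy on an aromatic carbon does to growth inhibition in this assay.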